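The source may hold more compounds than are shown below. What is called first, only, known or untested is meant among the compounds shown, and "the series" means these compounds.

Measured compounds: compound 1 `CNC(=O)c1cc(C(=O)NC2CCC2)cn(Cc2ccncc2)c1=O` and compound 2 `CNC(=O)c1cc(C(=O)NC2CC2)cn(Cc2cccc([C@@H](C)O)c2)c1=O`.

In a physicochemical assay for solubility (on this read-out higher numbers stand for higher solubility and lower numbers for lower solubility), compound 1 reports only a limit of the assay, >= 118 ug/mL. In this assay compound 2 also reports a limit rather than a number, >= 131 ug/mL. Compound 2 therefore stands at the limit of >= 131 ug/mL in this assay, at which 1 of the 2 values shown sits, with no exact figure known.

Compound 3 `CNC(=O)c1cc(C(=O)NC2CC2)cn(CC2CCCCC2)c1=O` is not yet measured. It differs from compound 2 in one place: cyclohexyl in place of 3-(1-hydroxyethyl)phenyl on a saturated chain carbon bound to an aromatic nitrogen. Among the compounds with values here, no step between measured compounds is available. In this assay the expected step is a fall beyond the usual scatter, an at least 3.2-fold lower number from compound 2 to compound 3 (0.51 log units; beyond the scatter). Compound 3 is estimated at 40 ug/mL, in the range 10 ug/mL to 130 ug/mL.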

Compound 3, solubility: >= 148 ug/mL
Compound 3: only a limit was reported; the forecaster's own chance of this, stated with the estimate: 20%; middle value at least 3.7-fold (0.56 log units) from the limit.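

Within the data shown here, compound 2 and compound 3 both report only limits in this assay, so no step between them can be read. The compounds shown leave open what exact solubility lies behind any of these limits.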